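Aryl amide series: from compound 3 to compound 4

This account rests on a few compounds, and the source may have more. Where it says the series, first, only, none or still open, it means among the compounds named here.

In a physicochemical assay, with a stated time of 30 min (a lower number here means a stronger inhibitor, a higher number a weaker inhibitor), compound 1 `CCc1ccc(NC(=O)C2Cc3cc(OC)c(OC)cc3C2=O)cc1` gives 76.2 ug/mL and compound 2 `COc1ccc(NC(=O)C2Cc3cc(OC)c(OC)cc3C2=O)cc1` gives 49.5 ug/mL while compound 3 `COc1cc2c(cc1OC)C(=O)C(C(=O)Nc1ccc(Br)cc1)C2` gives 72.1 ug/mL and so stands within the scatter of both others.

The next structure is compound 4 `COc1cccc(NC(=O)C2Cc3cc(OC)c(OC)cc3C2=O)c1` with 3-methoxyphenyl in place of 4-bromophenyl on an amide-type nitrogen.

Among the measured compounds shown here, two measured steps bear on this change. The exchange of methoxy for bromo on an aromatic carbon appears in a 1.5-fold higher number from compound 2 to compound 3 (0.16 log units; within the scatter) and is the closest case. The step of a 1.1-fold lower number from compound 1 to compound 3 (0.02 log units; within the scatter) and the step of a 1.5-fold lower number from compound 1 to compound 2 (0.19 log units; within the scatter) show that the other exchanges on that aromatic carbon also stay small. For the measured compounds named here, no measured step covers a change in where the group sits on the aromatic ring, so that part of the change remains untested.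

No step beyond the scatter is expected, and the estimated step is a 1.2-fold lower number from compound 3 to compound 4 (0.08 log units; within the scatter) in this series.

For compound 4 the estimated value is 60 ug/mL and 36 ug/mL to 100 ug/mL is the expected range.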

Compound 4, half-maximal inhibitory concentration: 38.9 ug/mL
Estimate against measurement, compound 4: 1.5-fold (0.19 log units) above, and the stated range covers the measured number.
By their numbers in this assay, from the lowest: compounds 4, 2, 3 and 1 (each within the scatter of the next).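

In this assay, among the compounds shown here, the exchange of 4-methoxyphenyl for 3-methoxyphenyl on the amide-type nitrogen gives the first direct reading of where the methoxy group sits on the ring: a 1.3-fold lower number from compound 2 to compound 4 (0.10 log units; within the scatter). For the compounds shown here, the exchanges that alter both the group and its place on the ring give a 1.9-fold lower number from compound 3 to compound 4 (0.27 log units; within the scatter) and a 2.0-fold lower number from compound 1 to compound 4 (0.29 log units; within the scatter), so all four aryl groups on this nitrogen remain within the scatter of one another, and compound 4 gives no step that stands beyond it. No measured property is available to explain these small steps.

Going by these compounds, whether an amine or a carboxylic acid on the aryl ring, or a longer chain on it, would give a step beyond the scatter remains open. Changes to the shared core also remain open, since all four compounds carry it unchanged.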